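From dimethoxyphenyl to dihydroxyphenyl on a shared core

A few compounds are considered here, and "the series" means these few. Any claim that something is new, unique, unknown or untested is made for them only; others in the source may bear on it.

Compound 1 `CCOC(=O)c1cnn(-c2nc(-c3cccc(OC)c3OC)c(C#N)c(=O)n2C)c1N` gives 57 ug/mL
Compound 2 `Cn1c(NN)nc(-c2cccc(O)c2O)c(C#N)c1=O` gives 31 ug/mL
Compound 3 `CSc1nc(-c2cccc(O)c2O)c(C#N)c(=O)n1C` gives 41 ug/mL

All three numbers come from a functional assay on microsomes for inhibition, with a stated time of 1 h (on this read-out lower numbers stand for stronger inhibition and higher numbers for weaker inhibition), and lie within the usual scatter of one another, so compound 1 does not stand apart from the other two. Compound 4 `CCOC(=O)c1cnn(-c2nc(-c3cccc(O)c3O)c(C#N)c(=O)n2C)c1N` differs from compound 1 in one place, 2,3-dihydroxyphenyl in place of 2,3-dimethoxyphenyl on an aromatic carbon on an aromatic carbon ortho to a cyano group.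

Going by the values given here, no measured pair isolates this swap. Among the compounds with values here, the only measured step, a 1.3-fold higher number from compound 2 to compound 3 (0.12 log units; within the scatter), changes a different group while 2,3-dihydroxyphenyl stays in place. It shows that two compounds carrying 2,3-dihydroxyphenyl give similar numbers, but not what the swap itself does. Compound 2 (31 ug/mL) and compound 3 (41 ug/mL) are within the scatter of compound 1, so no step beyond the scatter is expected, with only a slight lean towards a lower number.

The expected step in this assay is a 1.4-fold lower number from compound 1 to compound 4 (0.15 log units; within the scatter) as an estimate.

Compound 4 is expected at 40 ug/mL (estimated range 18 ug/mL to 90 ug/mL).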

Compound 4, half-maximal inhibitory concentration: 49 ug/mL
Estimate against measurement, compound 4: 1.2-fold (0.09 log units) below, and the stated range covers the measured number.
By their numbers in this assay, from the lowest: compounds 2, 3, 4 and 1 (each within the scatter of the next).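

Going by these compounds alone, with everything else in the molecule held fixed, this pair gives the first direct reading of the swap: in this assay, 2,3-dihydroxyphenyl in place of 2,3-dimethoxyphenyl gives a 1.2-fold lower number from compound 1 to compound 4 (0.07 log units; within the scatter). At this aromatic carbon ortho to a cyano group, the read-out therefore does not separate the two groups, even though 2,3-dihydroxyphenyl carries hydrogen-bond donors and 2,3-dimethoxyphenyl has none. No measurement shown here bears on why the two groups give such similar numbers.

On these data alone, it remains open whether a group of another kind at this position, such as a plain phenyl or an aminophenyl, would move the number beyond the scatter. As far as these compounds go, it is also open whether the same swap would read the same way in compound 2 or compound 3, which carry different groups elsewhere on the shared core.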